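Three flat neighbours and a methylsulfanyl swap

The source may hold more compounds than are shown below. What is called first, only, known or untested is meant among the compounds shown, and "the series" means these compounds.

compound 1 `COc1ccc(-c2nc3cc[nH]cc-3n2)c(OC)c1` gives 0.3 mg/kg
compound 2 `COc1cc(Cl)ccc1-c1nc2cc[nH]cc-2n1` gives 0.23 mg/kg
compound 3 `COc1cc(C)ccc1-c1nc2cc[nH]cc-2n1` gives 0.28 mg/kg

These values come from a functional assay on the whole organism with Canis familiaris (Canis lupus familiaris) as the target (a higher number here means that more compound is needed for the effect, a lower number that less compound is needed), and compound 3 at 0.28 mg/kg lies within the scatter of both others. Compound 4 `COc1cc(SC)ccc1-c1nc2cc[nH]cc-2n1` carries the change methylsulfanyl in place of methyl on an aromatic carbon with methylsulfanyl in place of methyl on an aromatic carbon. For the measured compounds named here, three measured steps concern that same carbon: a 1.1-fold lower number from compound 1 to compound 3 (0.03 log units; within the scatter) and a 1.2-fold higher number from compound 2 to compound 3 (0.09 log units; within the scatter) and a 1.3-fold lower number from compound 1 to compound 2 (0.12 log units; within the scatter) all stayed within the scatter. Going by the values given here, no measured compound carries methylsulfanyl, so this rests on methoxy, chloro and methyl alone. The expected size is therefore none beyond the scatter, with the estimated 1.0-fold lower number from compound 3 to compound 4 (0.02 log units; within the scatter) as the step. For compound 4 the estimate is 0.27 mg/kg with an expected range from 0.13 mg/kg to 0.55 mg/kg in this measurement.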

Compound 4, dose for half-maximal effect: 0.2 mg/kg
For compound 4 the middle estimate is 1.4-fold (0.13 log units) above the measured one, and the stated range covers the measured number.
By their numbers in this assay, from the lowest: compounds 4, 2, 3 and 1 (each within the scatter of the next).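

In this assay methylsulfanyl on this aromatic carbon stays within the scatter of all three earlier groups (a 1.4-fold lower number from compound 3 to compound 4 (0.15 log units; within the scatter); a 1.2-fold lower number from compound 2 to compound 4 (0.06 log units; within the scatter); a 1.5-fold lower number from compound 1 to compound 4 (0.18 log units; within the scatter)). A sulfur-bearing group with two heavy atoms therefore joins methoxy, chloro and methyl here without any step beyond the scatter, so these four groups cannot be ranked at this carbon. No evidence is available to explain this flatness. Going by these compounds, whether an amine or a carboxylic acid on this carbon would give a step beyond the scatter remains open, as does the outcome with a longer chain.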